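The compounds below may be only part of what the source reports. "The series", "measured", "known", "first", "only" and "open" are said of these compounds alone.

In a functional assay on Huh-7 cells (Homo sapiens) for cytotoxicity, read by MTT assay, with a stated time of 3 days; a lower number here means that less compound is tolerated, a higher number that more compound is tolerated:
Compound 1 `CSCc1ncnc2c1ncn2[C@@H]1O[C@H](CO)[C@@H](O)[C@H]1O`: > 100000 nM, a limit of the assay
Compound 2 `CN(Cc1ccccc1)Cc1ncnc2c1ncn2[C@@H]1O[C@H](CO)[C@@H](O)[C@H]1O`: 9000 nM

Within the data shown here, compound 2 holds the only actual number so far. Compound 3 `CC(=O)N(Cc1ccccc1)Cc1ncnc2c1ncn2[C@@H]1O[C@H](CO)[C@@H](O)[C@H]1O` differs from it by acetyl in place of methyl on an amine nitrogen, with acetyl in place of methyl on an amine nitrogen. Among the measured compounds shown here, the sole measured step, an at least 11-fold lower number from compound 1 to compound 2 (1.04 log units; beyond the scatter), is large and brought in the benzyl(methyl)amino group that this change alters. For the measured compounds named here, with that one step as the only guide, a moderate move toward a higher number is expected in this assay, beyond the scatter but uncertain in size. The expected step is a 2.8-fold higher number from compound 2 to compound 3 (0.44 log units; beyond the scatter). For compound 3 the estimate is 25000 nM, with an expected range of 8000 nM to 100000 nM.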

Compound 3, half-maximal cytotoxic concentration: > 100000 nM
Compound 3: no number, only a limit (the forecaster's own chance of this, stated with the estimate: 35%); middle value at least 4.0-fold (0.60 log units) away from the limit.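

In this assay, acetyl in place of methyl on an amine nitrogen gives an at least 11-fold higher number from compound 2 to compound 3 (1.04 log units; beyond the scatter). Compound 3 gives > 100000 nM, which is a limit of the assay. The benzyl group stays in place in compound 3, so a change on this nitrogen alone is enough to separate a readable number from the top of the range: the limit of > 100000 nM in this assay, at which 2 of the 3 values shown sit.

On these data alone, whether the readable number depends on methyl at this nitrogen stays open, as an ethyl chain, a benzoyl group or a plain hydrogen there could read either way. As far as these compounds go, the full size of the step also stays open.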